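A few compounds are considered here, and "the series" means these few. Any claim that something is new, unique, unknown or untested is made for them only; others in the source may bear on it.

Three compounds share one core, and all three reach the same limit in an ADME assay on HepG2 cells (Homo sapiens) for cytotoxicity, with a stated time of 72 h; a lower number here means that less compound is needed, a higher number that more compound is needed for the effect. Compound 1 `Cc1cc(NC(=O)Nc2ccc(C)c(Cl)c2)c2ccccc2n1` gives > 25000 nM in this assay, which is a limit of the assay and not a number. Compound 3 `CSc1ccccc1NC(=O)Nc1cc(C)nc2ccccc12` likewise gives > 25000 nM in this assay, again a limit. Compound 2 `Cc1ccc(NC(=O)Nc2cc(C)nc3ccccc23)cc1` gives > 25000 nM in this assay, also a limit, so compound 2 stands exactly where everything else shown stands: the limit of > 25000 nM in this assay, at which 3 of the 3 values shown sit. Going by the values given here, the one measured step, a step that the two limits leave unreadable from compound 1 to compound 2, has a limit at each end and therefore carries no readable size.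

Compound 4 `COC(=O)c1ccc(NC(=O)Nc2cc(C)nc3ccccc23)cc1` differs from compound 2 by methoxycarbonyl in place of methyl on an aromatic carbon. No measured step bears on this change: the only step known is unreadable, and nothing shown tells what methoxycarbonyl in place of methyl does in this assay. For compound 4, the expected step is a step that the limit leaves unreadable from compound 2 to compound 4, that is, nothing beyond the scatter. The estimate for compound 4 is 30000 nM, expected to lie between 8000 nM and 120000 nM, most likely reported again as a limit.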

Compound 4, half-maximal effective concentration: 20000 nM
Compound 4: the middle estimate sits 1.5-fold (0.18 log units) above what was measured; measured number inside the range.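

In this assay, going by these compounds alone, compound 4 gives 20000 nM as a number and not a limit, so methoxycarbonyl in place of methyl, on an aromatic carbon para to a large group, gives the first readable value. The change reads as an at least 1.2-fold lower number from compound 2 to compound 4 (0.09 log units; that floor lies within the scatter) and so marks only a floor, with no change established beyond the scatter. This one number stands alone among limits: the limit of > 25000 nM in this assay, at which 3 of the 4 values shown sit.

On these data alone, how far the true step lies from that floor stays open, as compound 2 has only a limit and no number. The compounds shown also leave open whether a carboxylic acid, an amine or a longer chain on this same aromatic carbon would give a readable value, and how it would compare with compound 4.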